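Furan-2-yl to 4-chlorophenyl on the shared core

The source may hold more compounds than are shown below. What is called first, only, known or untested is meant among the compounds shown, and "the series" means these compounds.

Compound 1 `Clc1ccc(-c2cc(-c3ccco3)nc(-c3cccs3)c2)o1` gives 16% in an assay on isolated protein for inhibition of DNA topoisomerase 1 (Homo sapiens), tested at 100 uM; a higher number here means a stronger effect of the compound at the concentration tested, a lower number a weaker effect. Of the three numbers in hand, compound 1's is the highest; compound 2 `Cc1ccc(-c2cc(-c3ccc(Cl)o3)cc(-c3ccsc3)n2)o1` with 9.1% stands within the scatter of it, while compound 3 `Clc1ccc(-c2cc(-c3ccsc3)nc(-c3ccccn3)c2)o1` with 0% lies beyond it. Among the measured compounds shown here, the only single-point step among the measured compounds, a number 9.1 percentage points lower from compound 2 to compound 3 (within the scatter), exchanges one aromatic group for another on the core and stays within the scatter.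

Compound 4 `Clc1ccc(-c2cc(-c3ccc(Cl)o3)cc(-c3cccs3)n2)cc1` differs from compound 1 by 4-chlorophenyl in place of furan-2-yl on an aromatic carbon. For the measured compounds named here, no measured step covers this particular exchange, so the bearing of the data is indirect: the one aromatic-for-aromatic swap seen so far, from compound 2 to compound 3, moved the read-out only within the scatter. The same is expected here, with no step beyond the scatter and, if anything, a slight fall. The expected step of a number 4 percentage points lower from compound 1 to compound 4 (within the scatter) is estimated to lie within the scatter. Compound 4 is therefore expected to give about 12%, in a range from 0% to 28%.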

Compound 4, a percentage reported as inhibition, at one concentration (the size of the read-out at that concentration, not a potency): 38.9%
Beside the measured number, compound 4's estimate is 26.9 percentage points below it; measured number above the stated range.
By their numbers in this assay, from the lowest: compounds 3, 2 and 1 (each within the scatter of the next, the first and the last beyond it); then compound 4.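

With 4-chlorophenyl in place of furan-2-yl on the aromatic carbon next to the ring nitrogen, this assay shows a number 22.9 percentage points higher from compound 1 to compound 4 (beyond the scatter). Among the compounds shown here, this is the first single-place step to pass beyond the scatter, whereas a number 9.1 percentage points lower from compound 2 to compound 3 (within the scatter) did not, so an exchange of one aromatic group for another on the shared core does not always leave the read-out unchanged. No evidence at hand bears on the origin of this step.

Still open, from the compounds shown here alone, is whether the step follows the chlorine or the six-membered carbon ring itself, a question that a plain phenyl group or a 4-aminophenyl group at this position would address. The read-out comes from a single concentration, so the step also leaves potency open.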